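This account rests on a few compounds, and the source may have more. Where it says the series, first, only, none or still open, it means among the compounds named here.

Measured compounds:
compound 1 `C=CCn1c(=O)/c(=C\c2cccc(Cl)c2)[nH]c(=O)/c1=C\c1ccccc1OC` with 4900 nM in a functional assay on MOLT-4 cells (Homo sapiens) for cytotoxicity, read by CCK-8 assay, with a stated time of 72 h; a higher number here means a weaker inhibitor, a lower number a stronger inhibitor
compound 2 `COc1ccccc1/C=c1/[nH]c(=O)/c(=C\c2cccc(Cl)c2Cl)[nH]c1=O` with "not determined" (no result reported) in this assay
compound 3 `C=CCn1c(=O)/c(=C\c2ccccc2Cl)[nH]c(=O)/c1=C\c1ccccc1OC` with 4400 nM in this assay

Among the compounds with values here, compound 3 and compound 1 give numbers that lie within the scatter of each other; compound 2 carries no result in this assay, so only two numbers frame the series. Within the data shown here, the one measured step, a 1.1-fold lower number from compound 1 to compound 3 (0.05 log units; within the scatter), shows that moving the chlorine on the ring bound to the double-bonded chain carbon leaves the number essentially unchanged.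

Compound 4 `C=CCn1c(=O)/c(=C\c2ccc(Cl)c(Cl)c2)[nH]c(=O)/c1=C\c1ccccc1OC` differs from compound 3 by 3,4-dichlorophenyl in place of 2-chlorophenyl on a double-bonded chain carbon bound to an aromatic carbon. Among the measured compounds shown here, the step from compound 1 to compound 3 is the only one that bears on this change, and it was within the scatter; no measured pair tests a second chlorine on that ring. Compound 4 is therefore expected to sit close to compound 3, with a 1.1-fold lower number from compound 3 to compound 4 (0.04 log units; within the scatter) as the estimated step and no change beyond the scatter foreseen. The estimate for compound 4 is 4000 nM, within a range from 1500 nM to 12000 nM.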

Compound 4, half-maximal inhibitory concentration: "not active" (no number reported)
Compound 4 has no reported number here, so the estimate cannot be set against anything.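

In this assay, within the data shown here, compound 4 is reported as not active with no number, so no step from compound 3 to compound 4 can be read. No evidence shown here bears on this result. The compounds shown leave open how a second chlorine on that ring affects the number.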